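This account rests on a few compounds, and the source may have more. Where it says the series, first, only, none or still open, it means among the compounds named here.

Two amides on the shared core have been measured in a functional assay on the whole organism for inhibition, with Brassica rapa subsp. chinensis as the target, with a stated time of 3 days, tested at 100 ppm; on this read-out higher numbers stand for more inhibition of growth at the one concentration tested and lower numbers for less inhibition of growth. Compound 1 `CCc1ccccc1NC(=O)/C=C/c1ccccc1` gives 0% in this assay, and compound 2 `CC(C)NC(=O)/C=C/c1ccccc1` gives 39%. Compound 2 thus stands highest of the two numbers; its nearest neighbour is compound 1, whose number lies lower by a gap beyond the usual scatter. Among the measured compounds shown here, no two measured compounds differ in only one place, so no single-site step can be read from the measured set.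

Compound 3 `C=CCNC(=O)/C=C/c1ccccc1` has not yet been measured. It differs from compound 2 in one place: allyl in place of isopropyl on an amide-type nitrogen. Both the group that leaves and the group that enters are short open chains carrying no donor, no acceptor and no charge, and they sit on the same amide-type nitrogen. For the measured compounds named here, the measured pair offers no precedent for this exchange. For the step from compound 2 to compound 3 a small change is expected, most likely within the scatter, with a slight drop no less plausible than no change: a number 4 percentage points lower from compound 2 to compound 3 (within the scatter) is the expected step. Compound 3 is accordingly estimated at 35% in this assay, with a range from 10% to 60%.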

Compound 3, percent growth inhibition at one concentration: 63%
The estimate for compound 3 lay 28 percentage points below the measured number, outside the stated range (above it).
By their numbers in this assay, from the lowest: compound 1; then compound 2; then compound 3.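

In this assay, among the compounds shown here, the exchange of isopropyl for allyl on an amide-type nitrogen gives a number 24 percentage points higher from compound 2 to compound 3 (beyond the scatter), the only single-place step so far, and it shows that this position is sensitive to the choice of a short open chain. The two groups have the same heavy-atom count, all carbon, with no ring, no hydrogen-bond donors or acceptors and no net charge; the computed difference between them is the double bond outside aromatic rings that allyl carries, together with the change in chain shape from isopropyl to allyl. Nothing at hand accounts for the size of this step.

Whether the gain follows the double bond or the unbranched shape of the chain stays open, since propyl, the saturated unbranched chain that would separate the two, is not among the compounds shown. Also open, on these data alone, is how far the position tolerates other groups on this nitrogen, such as propargyl, a longer chain such as butyl or pentyl, or a cyclopropylmethyl group, and whether any of them would stand above compound 3 on this read-out.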